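Amino in place of hydrogen: from compound 3 to compound 4

A few compounds are considered here, and "the series" means these few. Any claim that something is new, unique, unknown or untested is made for them only; others in the source may bear on it.

The set is small. Compound 1 `O=c1ccn(COCCO)c(=O)[nH]1` and compound 2 `O=c1cc(O)ccn1COCCO` share a chain bearing an oxygen and a terminal hydroxyl, each on a different single-ring core. In a functional assay (Oryctolagus cuniculus) for inhibition (a higher number here means a weaker inhibitor, a lower number a stronger inhibitor), compound 1 reaches only a limit of the assay, > 400 ug/mL. For compound 2 the same assay again reports a limit rather than a number, > 400 ug/mL. Compound 3 `CC(=O)OCCOCn1cnc2c(Cl)ncnc21` carries an acetylated chain on a fused two-ring core with a chloro group, and in this assay compound 3 gives 60 ug/mL. So compound 3 stands as the only compound with a measured number, while the other two values sit at the limit (the limit of > 400 ug/mL in this assay, at which 2 of the 3 values shown sit).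

Compound 4 `CC(=O)OCCOCn1cnc2c(Cl)nc(N)nc21` keeps the whole of compound 3 and differs in one place: amino in place of hydrogen on an aromatic carbon. Going by the values given here, no step between two measured compounds is available, so the size of this change can only be guessed. The account expects a modest gain, with the step from compound 3 to compound 4 estimated at a 1.7-fold lower number from compound 3 to compound 4 (0.23 log units; within the scatter), though a move of that size is not far beyond the scatter. Compound 4 is therefore estimated at 35 ug/mL, within a range from 8 ug/mL to 200 ug/mL.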

Compound 4, concentration for 50% inhibition: 55 ug/mL
Compound 4: middle estimate off by 1.6-fold (0.20 log units), on the low side, within the range that was stated.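

Going by these compounds alone, the step of a 1.1-fold lower number from compound 3 to compound 4 (0.04 log units; within the scatter) in this assay is the first in this set that can be read, and it lies within the scatter. Amino in place of hydrogen on this aromatic carbon, between two ring nitrogen atoms, therefore gives no difference that the measurement can separate from repeat scatter, and the chloro group and the acetylated chain stay the same throughout. This is the only single-place comparison available, and the two single-ring compounds, whose values are limits rather than numbers, add no second step to set beside it: the limit of > 400 ug/mL in this assay, at which 2 of the 4 values shown sit.

The compounds shown leave open whether the same holds for other groups on this carbon, such as a methylamino, a dimethylamino or an acetylamino group, none of which can be judged from a single amino step. They also leave open what this assay would report with a methoxy group or an amine in place of the chloro group, or with a free hydroxyl in place of the acetyl ester at the end of the chain on this fused core.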